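Solubility in a series of three and a fourth to come

The source may report more compounds than this note shows. Statements on the series, on what has been measured and on what is new or still open speak of the compounds shown alone.

Measured so far:
compound 1, `COc1cccc(CNCCCNc2ccnc3cc(C4CCCCC4)ccc23)c1O`, in a physicochemical assay for solubility, with a stated time of 18 h, at pH 7.4 (a higher number here means a more soluble compound, a lower number a less soluble compound), gives 4200 nM
compound 2, `COc1cccc(CNCCCNc2ccnc3cc(Cc4ccc(F)cc4)ccc23)c1O`, gives 4200 nM
compound 3, `COc1cccc(CNCCCNc2ccnc3cc(Cc4ccc(C#N)cc4)ccc23)c1O`, gives 4200 nM

All three compounds share one core and differ only in the group carried on one aromatic carbon of it. Compound 3 sits level with compounds 1 and 2 on the numbers shown; its nearest neighbour is compound 1 and its furthest is compound 2, and neither gap goes beyond the scatter.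

Compound 4, `COc1ccccc1Oc1ccc2c(NCCCNCc3cccc(OC)c3O)ccnc2c1`, is the next member. Its change from compound 3 is 2-methoxyphenoxy in place of 4-cyanobenzyl on an aromatic carbon.

Within the data shown here, three measured steps bear on this change, each a swap of the group at that same aromatic carbon: no change at the digits printed from compound 1 to compound 2 (within the scatter), no change at the digits printed from compound 1 to compound 3 (within the scatter) and no change at the digits printed from compound 2 to compound 3 (within the scatter). None of them moved this assay beyond its scatter, even though the groups swapped ranged from a saturated ring to substituted benzyl groups. The step to compound 4 again replaces one nine-atom group with another at the same place. On this basis the expectation for compound 4 in this assay is a step of about no change at the digits printed from compound 3 to compound 4 (within the scatter), that is, no change beyond the scatter. Compound 4 is therefore estimated at 4200 nM, within a range from 1500 nM to 12000 nM.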

Compound 4, solubility: 14500 nM
For compound 4 the middle estimate is 3.5-fold (0.54 log units) below the measured one; measured number above the stated range.
By their numbers in this assay, from the lowest: compounds 1, 2 and 3 (each within the scatter of the next); then compound 4.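

In this assay there is a 3.5-fold higher number from compound 3 to compound 4 (0.54 log units; beyond the scatter) and a 3.5-fold higher number from compound 2 to compound 4 (0.54 log units; beyond the scatter) and a 3.5-fold higher number from compound 1 to compound 4 (0.54 log units; beyond the scatter) once 2-methoxyphenoxy stands on this aromatic carbon, so the number at this position can move beyond the scatter, which the cyclohexyl, 4-fluorobenzyl and 4-cyanobenzyl groups alone did not show. The step from the 4-cyanobenzyl group comes with no difference in the printed size count, as both groups hold 9 heavy atoms and one six-membered aromatic ring of carbon only, while the entering group has 7 carbon and 2 oxygen atoms where the leaving group has 8 carbon and 1 nitrogen, and 2 hydrogen-bond acceptors where it has 1. No measurement at hand explains the step.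

The compounds shown leave open whether the step goes with the oxygen joining the ring to the core or with the methoxy group on that ring. A plain phenoxy group and a 4-methoxybenzyl group on the same carbon would pull those two features apart in this assay and show which of them, if either, travels with the higher number.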